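Chloro in Place of (Isopropylcarbonyl)amino on Compound 3

The source may hold more compounds than are shown below. What is called first, only, known or untested is meant among the compounds shown, and "the series" means these compounds.

In an ADME assay on L6 cells (Rattus norvegicus) for cytotoxicity, read by resazurin assay, with a stated time of 72 h (a lower number here means a stronger inhibitor, a higher number a weaker inhibitor), compound 1 `OC(c1ccc(Cl)cc1)(c1cccnc1)c1ccccc1Cl` gives 61300 nM, compound 2 `OC(c1ccc(Cl)cc1)(c1ccc(Br)cc1)c1cccnc1` gives 57000 nM and compound 3 `CC(C)C(=O)Nc1ncc(C(O)(c2ccc(Cl)cc2)c2cccnc2)s1` gives 56600 nM. Compound 3 thus stands level with the other two, within the scatter of both. Compound 4 `OC(c1ccc(Cl)cc1)(c1cccnc1)c1cnc(Cl)s1` differs from it by chloro in place of (isopropylcarbonyl)amino on an aromatic carbon, with chloro in place of (isopropylcarbonyl)amino on an aromatic carbon. For the measured compounds named here, no measured step covers this exchange. The only one available, a 1.1-fold lower number from compound 1 to compound 2 (0.03 log units; within the scatter), swaps a different group and stays within the scatter. On that slender evidence, the expected change is a 1.0-fold lower number from compound 3 to compound 4 (0.01 log units; within the scatter), with no shift beyond the scatter anticipated in this assay. Compound 4 is estimated at 55000 nM, with an expected range from 25000 nM to 110000 nM.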

Compound 4, half-maximal inhibitory concentration: > 100000 nM
Compound 4: a limit, no number; the forecaster's own chance of this, stated with the estimate: 15%; at least 1.8-fold (0.25 log units) between middle value and limit.
By their numbers in this assay, from the lowest: compounds 3, 2 and 1 (each within the scatter of the next). At a limit, above all of these: compound 4.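

In this assay, compound 4 alone sits at a limit, which is not a number: the limit of > 100000 nM in this assay, at which 1 of the 4 values shown sits. For the compounds shown here, putting chloro in place of (isopropylcarbonyl)amino on this aromatic carbon gives an at least 1.7-fold higher number from compound 3 to compound 4 (0.24 log units; that floor lies within the scatter), so this is the first exchange that may move the number beyond the scatter, though its floor does not show that. The steps of an at least 1.7-fold higher number from compound 2 to compound 4 (0.24 log units; that floor lies within the scatter) and an at least 1.6-fold higher number from compound 1 to compound 4 (0.21 log units; that floor lies within the scatter) carry the same reservation.

The compounds shown leave open the true size of these steps. They also leave open how an amine, a carboxylic acid or a longer acyl chain on this carbon would read.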